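Hydroxypropyl in Place of Isopropyl on a Weak Binder

The source may hold more compounds than are shown below. What is called first, only, known or untested is meant among the compounds shown, and "the series" means these compounds.

Compound 1, `CC(C)n1cnc2ncnc(N)c21`: 20000 nM
Compound 2, `Nc1ncnc2c1ncn2C1CCC1`: 8700 nM

Of the compounds shown here, two sharing one core have been measured in an assay on CHO cells for displacement of a labelled ligand from adenosine receptor A1 (Homo sapiens); on this read-out lower numbers stand for stronger inhibition and higher numbers for weaker inhibition. Compound 1 gives 20000 nM, the higher of the two numbers, which means the weaker binding of the pair. Its nearest neighbour is compound 2, which in this assay gives 8700 nM, a difference that lies beyond the usual scatter. Within the data shown here, the two differ in more than one place, so no single step between measured compounds can be read from them.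

Compound 3, `Nc1ncnc2ncn(CCCO)c12`, differs from compound 1 by 3-hydroxypropyl in place of isopropyl on an aromatic nitrogen. Both measured compounds bind only weakly, and nothing measured shows how a chain carrying a hydroxyl on this ring nitrogen behaves. The most cautious expectation is a small step, quite possibly none beyond the scatter, in either direction; the step expected is no change at the digits printed from compound 1 to compound 3 (within the scatter). For compound 3 the estimated value in this assay is 20000 nM, with a range expected from 6000 nM to 60000 nM.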

Compound 3, inhibition constant: > 100000 nM
Compound 3: a limit, no number; the forecaster's own chance of this, stated with the estimate: 30%; at least 5.0-fold (0.69 log units) between middle value and limit.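

In this assay, compound 3 gives > 100000 nM, which is a limit of the assay and not a number. Among these compounds, putting 3-hydroxypropyl in place of isopropyl on the aromatic nitrogen gives an at least 5.0-fold higher number from compound 1 to compound 3 (0.69 log units; beyond the scatter), the first single change that can be read here, and it shows that this position is not indifferent to what it carries, even on a core that already binds only weakly. The step has a known lower end but no known full size, and the same holds for any comparison with compound 3: the limit of > 100000 nM in this assay, at which 1 of the 3 values shown sits.

The change alters two things at once, lengthening the chain and adding a hydroxyl, so the compounds shown cannot tell which of the two goes with the loss of binding; a plain propyl chain on the same nitrogen would separate them. Also open, as far as these compounds go, is how the shorter 2-hydroxyethyl chain would fare, and whether an amine or a carboxylic acid at the end of the chain would give a number that can be read rather than another limit.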